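The source may hold more compounds than are shown below. What is called first, only, known or untested is meant among the compounds shown, and "the series" means these compounds.

Three esters of the shared core have been tested in a functional assay on Vero cells (Chlorocebus sabaeus) for cytotoxicity; on this read-out higher numbers stand for lower toxicity in this test and lower numbers for higher toxicity in this test. Compound 1 `COCCOC(=O)C(O)Cn1cnc2c(N)ncnc21` gives > 400 ug/mL, which is a limit of the assay rather than a number. Compound 3 `CCC(C)OC(=O)C(O)Cn1cnc2c(N)ncnc21` gives > 400 ug/mL, again a limit. Within the data shown here, compound 2 `CC(C)CCOC(=O)C(O)Cn1cnc2c(N)ncnc21` gives 400 ug/mL, the only number among the three. The other two readings sit at the limit of > 400 ug/mL in this assay, at which 2 of the 3 values shown sit. The step of a number no higher from compound 1 to compound 2 (the limit leaves the size open) and the step of a number no lower from compound 2 to compound 3 (the limit leaves the size open) are both left open in size by these limits. Compound 4 `CCCCCOC(=O)C(O)Cn1cnc2c(N)ncnc21` differs from compound 2 by propyl in place of isopropyl on a saturated chain carbon, two bonds along the chain from an oxygen next to a carbonyl group. Neither neighbouring step reads as a change, and no step beyond the scatter is expected for compound 4 in this assay. Compound 4 is therefore estimated to give 400 ug/mL, between 200 ug/mL and 800 ug/mL. The expected step is no change at the digits printed from compound 2 to compound 4 (within the scatter).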

Compound 4, minimum cytotoxic concentration: 200 ug/mL
The estimate for compound 4 lay 2.0-fold (0.30 log units) above the measured number; measured number inside the range.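

In this assay, the straight pentyl chain takes the place of the branched isopentyl chain with a 2.0-fold lower number from compound 2 to compound 4 (0.30 log units; within the scatter), so at this position this rearrangement of the same atoms cannot be told apart from repeat measurements. The readings an at least 2.0-fold lower number from compound 3 to compound 4 (0.30 log units; that floor lies within the scatter) and an at least 2.0-fold lower number from compound 1 to compound 4 (0.30 log units; that floor lies within the scatter) are floors only, set by a limit of the assay: the limit of > 400 ug/mL in this assay, at which 2 of the 4 values shown sit.

Going by these compounds, the true size of those two steps stays open. So does whether a chain longer than pentyl, or an ester chain carrying an amine or a carboxylic acid, would shift this read-out beyond the scatter.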